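This account rests on a few compounds, and the source may have more. Where it says the series, first, only, none or still open, it means among the compounds named here.

Compound 2, with the structure `Cc1ccc(-c2nn(-c3ccccc3)cc2CNc2ccc(Br)cc2)cc1`, gives 6760 nM in a functional assay on B16-F10 cells (Mus musculus) for antiproliferative activity, read by MTT assay, with a stated time of 48 h; on this read-out higher numbers stand for weaker inhibition and lower numbers for stronger inhibition. Its two companions sit within the usual scatter of it: compound 3, `Brc1ccc(NCc2cn(-c3ccccc3)nc2-c2ccc(Br)cc2)cc1`, gives 5270 nM, and compound 1, `Cc1ccc(NCc2cn(-c3ccccc3)nc2-c2ccc(Cl)cc2)cc1`, gives 3480 nM. Compound 4, `Cc1ccc(-c2nn(-c3ccccc3)cc2CNc2ccc(Cl)cc2)cc1`, has not been tested; it differs from compound 2 in one place: chloro in place of bromo on an aromatic carbon. Among the measured compounds shown here, only one measured step touches the same aromatic carbon, the swap of methyl for bromo, and it gave a 1.3-fold lower number from compound 2 to compound 3 (0.11 log units; within the scatter). Two exchanges at that carbon therefore left the read-out essentially where it was, and the swap of bromo for chloro is expected to do the same: the estimated step is a 1.1-fold lower number from compound 2 to compound 4 (0.05 log units; within the scatter). Compound 4 is accordingly estimated at 6000 nM, with a range from 3000 nM to 12000 nM.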

Compound 4, half-maximal inhibitory concentration: 6010 nM
Beside the measured number, compound 4's estimate is 1.0-fold (0.00 log units) below it; measured number inside the range.
By their numbers in this assay, from the lowest: compounds 1, 3, 4 and 2 (each within the scatter of the next).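

In this assay, chloro in place of bromo gives a 1.1-fold lower number from compound 2 to compound 4 (0.05 log units; within the scatter). Among the compounds shown here, the earlier step, a 1.3-fold lower number from compound 2 to compound 3 (0.11 log units; within the scatter), changed the other substituted benzene ring, so this is the first look at the ring carrying the amino link, where one halogen can replace the other without a shift beyond the scatter. No measurement shown bears on why the two halogens read alike. Still open, as far as these compounds go, is whether this carbon stays as flat with a group that is not a halogen, such as a methoxy group, a carboxylic acid or an amine.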